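The source may report more compounds than this note shows. Statements on the series, on what has been measured and on what is new or still open speak of the compounds shown alone.

Compound 1 `O=C1N/C(=N/c2csc(-c3ccc(Cl)cc3)c2)S/C1=C\c1ccc(O)cc1` gives > 50000 nM in a functional assay on MCF7 cells (Homo sapiens) for cytotoxicity, read by MTT assay, with a stated time of 72 h (a lower number here means a stronger inhibitor, a higher number a weaker inhibitor), which is a limit of the assay. Compound 2 `O=C1N/C(=N/c2csc(-c3ccc(Cl)cc3)c2)S/C1=C\c1ccc(F)cc1` gives > 50000 nM in this assay, also a limit. Compound 3 `Cc1ccc(/C=C2\S/C(=N\c3nc(-c4ccc(Cl)cc4)cs3)NC2=O)cc1` gives 400 nM in this assay.

Among the measured compounds shown here, compound 3 thus holds the only number in this assay, while the other two values sit at the limit of > 50000 nM in this assay, at which 2 of the 3 values shown sit. The change from compound 1 to compound 2, a step that the two limits leave unreadable from compound 1 to compound 2, cannot be read in size. Compound 4 `O=C1N/C(=N/c2nc(-c3ccc(Cl)cc3)cs2)S/C1=C\c1ccc2ccccc2c1` differs from compound 3 by naphthalen-2-yl in place of 4-methylphenyl on a double-bonded chain carbon bound to a double-bonded ring carbon. For the measured compounds named here, no measured step touches that part of the shared core, so nothing among the measured compounds argues for a shift beyond the scatter in this assay. The step from compound 3 to compound 4 is expected to be no change at the digits printed from compound 3 to compound 4 (within the scatter). Compound 4 is estimated at 400 nM, between 130 nM and 1500 nM.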

Compound 4, half-maximal inhibitory concentration: 300 nM
Beside the measured number, compound 4's estimate is 1.3-fold (0.12 log units) above it, within the range that was stated.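

In this assay, among the compounds shown here, naphthalen-2-yl in place of 4-methylphenyl gives a 1.3-fold lower number from compound 3 to compound 4 (0.12 log units; within the scatter) and is the first step here that can be read in size. It shows that this place, on a double-bonded chain carbon bound to a double-bonded ring carbon, holds 2 six-membered aromatic rings of carbon only as well as one, with no shift beyond the scatter. Nothing measured here explains why the two groups read alike.

Open is how an amine or a carboxylic acid on the aromatic ring at this place would read, since both groups shown are carbon only.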